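Shifting the Nitro Group on the Sulfonyl Ring

The source may report more compounds than this note shows. Statements on the series, on what has been measured and on what is new or still open speak of the compounds shown alone.

In a functional assay on HL-60 cells (Homo sapiens) for inhibition, read by CCK-8 assay, with a stated time of 48 h, tested at 20 uM (a lower number here means less inhibition of growth, a higher number more inhibition of growth at the concentration tested), compound 1 (`COc1ccc(S(=O)(=O)Oc2ccccc2/C=C(\C#N)C(=O)Nc2nnc(Cc3ccc(C)cc3)s2)cc1`) gives 100% and compound 2 (`Cc1ccc(Cc2nnc(NC(=O)/C(C#N)=C/c3ccccc3OS(=O)(=O)c3ccc([N+](=O)[O-])cc3)s2)cc1`) gives 17% as the lower of the two numbers. Compound 3 (`Cc1ccc(Cc2nnc(NC(=O)/C(C#N)=C/c3ccccc3OS(=O)(=O)c3ccccc3[N+](=O)[O-])s2)cc1`) differs from compound 2 by 2-nitrophenyl in place of 4-nitrophenyl on a sulfonyl sulfur with 2-nitrophenyl in place of 4-nitrophenyl on a sulfonyl sulfur. Within the data shown here, the only measured step, the large a number 83 percentage points lower from compound 1 to compound 2 (beyond the scatter) (beyond the scatter), swaps a different group on that same ring and so bears on this change only loosely. A smaller upward move is expected, an estimated a number 11 percentage points higher from compound 2 to compound 3 (beyond the scatter) in this series. Compound 3 is expected at 28% (5% to 70%).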

Compound 3, percent growth inhibition at one concentration: 33%
Estimate against measurement, compound 3: 5 percentage points below; measured number inside the range.
By their numbers in this assay, from the lowest: compound 2; then compound 3; then compound 1.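

Moving the nitro group matters in this assay: 2-nitrophenyl in place of 4-nitrophenyl on a sulfonyl sulfur gives a number 16 percentage points higher from compound 2 to compound 3 (beyond the scatter), so the read-out depends on where the nitro group sits on this ring, not only on its presence. The recovery is partial, however, with a number 67 percentage points lower from compound 1 to compound 3 (beyond the scatter), so compound 3 remains well short of compound 1. Nothing available explains these differences.

From the compounds shown here alone, whether an amine or a carboxylic acid on this ring would restore the inhibition seen with compound 1 remains open. So does whether moving the methoxy group would shift the number as moving the nitro group did.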